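A Second Chloro Added to Compound 1

A few compounds are considered here, and "the series" means these few. Any claim that something is new, unique, unknown or untested is made for them only; others in the source may bear on it.

Compound 1 `ClCc1cccc(Cn2cnc3ncnc(Cl)c32)c1` — 38900 nM
Compound 2 `ClCc1cccc(Cn2cnc3c(Cl)ncnc32)c1` — 6310 nM
Compound 3 `ClCc1ccc(Cn2cnc3nc(Cl)nc(Cl)c32)cc1` — 6020 nM

Of the compounds shown here, three have been tested in a functional assay on UACC-62 cells (Homo sapiens) for cytotoxicity, read by sulforhodamine B assay, with a stated time of 48 h; a lower number here means that less compound is tolerated, a higher number that more compound is tolerated. Compound 1 gives 38900 nM, the highest of the three numbers. Compound 2, in this assay, gives 6310 nM, and compound 3 gives 6020 nM; both stand well beyond the scatter below compound 1, while the two of them lie within the scatter of each other. Compound 3 is the only one that carries two chloro groups on the shared core, and it is also the only one with the para arrangement on the benzyl ring, so the two features cannot be told apart on what is measured.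

Compound 4 `ClCc1cccc(Cn2cnc3nc(Cl)nc(Cl)c32)c1` has not yet been measured. It differs from compound 1 by chloro in place of hydrogen on an aromatic carbon, giving it the same two chloro groups as compound 3 while keeping the benzyl pattern of compound 1. Among the measured compounds shown here, no measured pair defines this particular step. The numbers for compound 2 and compound 3 suggest that a second chloro on the core is accompanied by a lower number than compound 1 shows, and the expected step of a 4.9-fold lower number from compound 1 to compound 4 (0.69 log units; beyond the scatter) is therefore downward, beyond the scatter. Compound 4 is estimated at 8000 nM, with a range from 3000 nM to 25000 nM.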

Compound 4, concentration lethal to 50% of the cells: 4670 nM
Compound 4: middle estimate off by 1.7-fold (0.23 log units), on the high side, and the stated range covers the measured number.
By their numbers in this assay, from the lowest: compounds 4, 3 and 2 (each within the scatter of the next); then compound 1.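

With the benzyl pattern of compound 1 kept, chloro in place of hydrogen on the aromatic carbon between two ring nitrogen atoms gives an 8.3-fold lower number from compound 1 to compound 4 (0.92 log units; beyond the scatter) in this assay, so a lower number now goes with the second chloro group without any change on the benzyl ring. This separates the two features that compound 3 carried together: compound 3 at 6020 nM and compound 4 at 4670 nM differ only in the benzyl pattern and lie within the scatter of each other, so that difference in pattern does not show up in this pair. No supporting measurement accompanies the step, and the reason for it remains unknown.

The compounds shown leave open whether the step depends on the chloro group already on the core, since this carbon is seen changing only with that group present. They also leave open whether an amine or a methoxy group on the same carbon would go with a number like that of compound 4, or whether the lower number is particular to chloro.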